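Replacing the 3-chlorophenyl group on the highest-exposure compound

A few compounds are considered here, and "the series" means these few. Any claim that something is new, unique, unknown or untested is made for them only; others in the source may bear on it.

Values so far in an in vivo ADME assay on the whole organism (strain CD1) for pharmacokinetics, with Mus musculus as the target, at a dose of 200 mg/kg by the oral route (on this read-out higher numbers stand for higher exposure at the dose given and lower numbers for lower exposure), are as follows:

- compound 1 `CCOC(=O)c1c(-c2cccc(OCC)c2)[nH]c2cc(OC)ccc2c1=O` gives 2400 nM
- compound 2 `CCCOc1cccc(-c2[nH]c3cc(OC)ccc3c(=O)c2C(=O)OCC)c1` gives 1800 nM
- compound 3 `CCOC(=O)c1c(-c2cccc(Cl)c2)[nH]c2cc(OC)c(F)cc2c1=O` gives 66000 nM

Compound 3 has the highest of the three numbers, and its gaps to compound 1 and compound 2 both lie beyond the scatter. The next compound to be measured is compound 4 `CCOC(=O)c1c(-c2cc(F)cc(OC)c2)[nH]c2cc(OC)c(F)cc2c1=O`, which keeps the core of compound 3 and changes one group: 3-fluoro-5-methoxyphenyl in place of 3-chlorophenyl on an aromatic carbon. That group sits next to the ring nitrogen and ortho to an ethoxycarbonyl group.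

Among the measured compounds shown here, no measured step covers this exchange. For the measured compounds named here, the only single-place step is a 1.3-fold lower number from compound 1 to compound 2 (0.12 log units; within the scatter) and it concerns a saturated chain on an aryl oxygen, so it says little here. Compound 1 at 2400 nM also carries an oxygen on that aryl ring, but it differs from compound 3 in the core as well, so its low number cannot be assigned to the aryl group alone. A moderate fall is therefore expected rather than the whole gap. The expected change is a 3.3-fold lower number from compound 3 to compound 4 (0.52 log units; beyond the scatter) as a rough estimate in this assay for now. For compound 4 the estimated value is 20000 nM with an expected range from 5000 nM to 60000 nM at this dose.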

Compound 4, maximal plasma concentration: 1600 nM
Compound 4: the middle estimate sits 13-fold (1.10 log units) above what was measured, outside the stated range (below it).
By their numbers in this assay, from the lowest: compounds 4, 2 and 1 (each within the scatter of the next); then compound 3.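

In this assay the exchange of 3-chlorophenyl for 3-fluoro-5-methoxyphenyl on the shared core gives a 41-fold lower number from compound 3 to compound 4 (1.62 log units; beyond the scatter). Among the compounds shown here, this is the first step between compounds that differ in one place to lie beyond the scatter. For the compounds shown here, the only earlier single-place step concerned a saturated chain on an aryl oxygen and stayed within the scatter, so it gave no sign that this aryl group could matter so much. The high number of compound 3 therefore does not belong to the core alone: in this pair, it depends strongly on the group on the aromatic carbon next to the ring nitrogen and ortho to the ethoxycarbonyl group. Nothing at hand bears on the reason for this step.

The incoming group differs from the outgoing one in more than one respect, so the loss of chlorine, the addition of fluorine and the addition of methoxy cannot be separated. On these data alone, whether a 3-methoxyphenyl or a 3-fluorophenyl group on this core would stay nearer compound 3 or compound 4 remains open, as does whether 3-chloro-5-methoxyphenyl would keep the high number.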